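The source may report more compounds than this note shows. Statements on the series, on what has been measured and on what is new or still open speak of the compounds shown alone.

Measured compounds:
Compound 1, `COc1ccc(CN2CCC3(CC2)OC(OC)Cc2c3cnn2-c2ccccc2)cc1`: 1.5 nM
Compound 2, `CCCN1CCC2(CC1)OC(OC)Cc1c2cnn1-c1ccccc1`: 33 nM

Among the measured compounds shown here, in an assay for displacement of a labelled ligand from Sigma non-opioid intracellular receptor 1 (Cavia porcellus), read by scintillation counting, with a stated time of 180 min (on this read-out higher numbers stand for weaker inhibition and lower numbers for stronger inhibition), compound 1 gives the lowest of the two numbers, and the only measured step away from it is a 22-fold higher number from compound 1 to compound 2 (1.34 log units; beyond the scatter), a large step beyond the scatter. The unmeasured compound 3, `COC1Cc2c(cnn2-c2ccccc2)C2(CCN(CC(C)C)CC2)O1`, differs from compound 1 in one place: isopropyl in place of 4-methoxyphenyl on a saturated chain carbon bound to an amine nitrogen in a ring. The same difference, cut one bond further out, reads 4-methoxybenzyl to isobutyl.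

For the measured compounds named here, the one step that bears on this change is a 22-fold higher number from compound 1 to compound 2 (1.34 log units; beyond the scatter), in which ethyl in place of 4-methoxyphenyl on the saturated chain carbon bound to the ring amine nitrogen raised the number far beyond the scatter. Going by the values given here, compound 3 likewise carries a saturated group with no ring, isopropyl, where compound 1 carries 4-methoxyphenyl; no measured compound carries isopropyl there, so the expectation rests on the single measured step alone. Compound 3 is therefore expected to give 30 nM in this assay, within a range from 8 nM to 110 nM. That estimate means an expected step of a 20-fold higher number from compound 1 to compound 3 (1.30 log units; beyond the scatter), upward and beyond the scatter.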

Compound 3, inhibition constant: 6.3 nM
The estimate for compound 3 lay 4.8-fold (0.68 log units) above the measured number; measured number outside the range, below it.
By their numbers in this assay, from the lowest: compound 1; then compound 3; then compound 2.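

In this assay, the earlier step had suggested that losing 4-methoxyphenyl at this place would cost heavily, yet the change to isopropyl on a saturated chain carbon bound to an amine nitrogen in a ring gives only a 4.2-fold higher number from compound 1 to compound 3 (0.62 log units; beyond the scatter), a modest step that is still beyond the scatter. The side chain therefore need not hold an aromatic ring for the number to stay low, although 4-methoxybenzyl keeps a measurable edge over isobutyl. The two ring-free chains also differ clearly from each other, since methyl in place of hydrogen on a saturated chain carbon bound to two saturated chain carbons gives a 5.2-fold lower number from compound 2 to compound 3 (0.72 log units; beyond the scatter), and nothing in the data gives a reason for either step.

The compounds shown leave open whether the lower number follows the branching itself or the larger chain, which a straight butyl chain could separate, and whether a bulkier neopentyl or cyclohexylmethyl group would lower it further. They also leave open what the methoxy group adds to the ring, which a plain benzyl group would show.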